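This account rests on a few compounds, and the source may have more. Where it says the series, first, only, none or still open, it means among the compounds named here.

Measured so far:
Compound 1, `Cn1nc2c(=O)n(CC3(O)CCN(Cc4ccc(-c5ccco5)cc4Cl)CC3)cnc2c1-c1ccc(F)cc1`, gives 0.75 h in an ADME assay on microsomes from liver (Rattus norvegicus) for metabolic stability; on this read-out higher numbers stand for a longer-lived compound and lower numbers for a shorter-lived compound.
Compound 2, `Cn1nc2c(=O)n(CC3(O)CCN(Cc4ccc(C5=CCCC5)cc4Cl)CC3)cnc2c1-c1ccc(CN)cc1`, gives 2.33 h in this assay.

Compound 2 stands highest of the two numbers, and its gap to compound 1 lies beyond the usual scatter. Compound 3, `Cn1nc2c(=O)n(CC3(O)CCN(Cc4ccc(-c5ccc(C(=O)O)o5)cc4Cl)CC3)cnc2c1-c1ccc(CN)cc1`, differs from compound 2 in a single place: 5-carboxyfuran-2-yl in place of cyclopent-1-en-1-yl on an aromatic carbon. Among the compounds with values here, no pair of measured compounds covers a change of this kind, so the expectation rests on the number of compound 2 alone. The estimated step, a 1.1-fold higher number from compound 2 to compound 3 (0.03 log units; within the scatter), is expected to stay within the scatter, with no direction favoured. Compound 3 is therefore estimated at 2.5 h, in a range from 1 h to 6 h.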

Compound 3, half-life: 1.25 h
Estimate against measurement, compound 3: 2.0-fold (0.30 log units) above; the measured number falls inside the stated range.
By their numbers in this assay, from the lowest: compounds 1, 3 and 2 (each within the scatter of the next, the first and the last beyond it).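

Swapping cyclopent-1-en-1-yl for 5-carboxyfuran-2-yl, on the aromatic carbon meta to the chloro group and para to a large group, gives a 1.9-fold lower number from compound 2 to compound 3 (0.27 log units; within the scatter) in this assay. Within the data shown here, this is the first single-place step read at this position, and it stays within the scatter even though the entering group brings a hydrogen-bond donor and acceptors that the leaving group lacks. No measurement shown accounts for the size of this step. The compounds shown leave open whether a methyl ester or a primary amide in place of the carboxylic acid on the furan would keep the half-life of compound 3.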